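The source may report more compounds than this note shows. Statements on the series, on what has been measured and on what is new or still open speak of the compounds shown alone.

In a functional assay on NIH3T3 cells (Mus musculus) (on this read-out higher numbers stand for an effect only at larger amounts of compound and lower numbers for an effect already at smaller amounts), compound 2 `N#Cc1ccc(Cn2cncc2CNc2ccc(C(=O)NCC3CCCCC3)c(-c3ccccc3)c2)cc1` gives > 10 uM, which is a limit of the assay and not a number. Compound 1 `CSCC[C@H](NC(=O)c1ccc(NCc2cncn2Cc2ccc(C#N)cc2)cc1-c1ccccc1)C(=O)O` gives > 10 uM, also a limit. The measured evidence so far is the limit of > 10 uM in this assay, at which 2 of the 2 values shown sit.

Compound 3 `CSCNC(=O)c1ccc(NCc2cncn2Cc2ccc(C#N)cc2)cc1-c1ccccc1` has methylsulfanyl in place of cyclohexyl on a saturated chain carbon bound to an amide-type nitrogen. Going by the values given here, the one measured step that bears on this change is a step that the two limits leave unreadable from compound 1 to compound 2. It alters the same amide-type nitrogen substituent but gives no size to carry over, so no direction can be drawn from it. With only this to go on, no clear shift in this assay is expected, and a further limit reading is the likeliest outcome. The estimated step is a step that the limit leaves unreadable from compound 2 to compound 3. The expected value for compound 3 is 15 uM, with an estimated range of 4 uM to 50 uM.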

Compound 3, concentration for half-maximal effect: > 10 uM
Compound 3 ended at the assay's limit (the forecaster's own chance of this, stated with the estimate: 75%); the middle value lies beyond the limit too.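

In this assay compound 3 gives > 10 uM, a limit and not a number, and the steps among compound 1, compound 2 and compound 3 cannot be read. The compounds shown leave open whether any substituent on the amide-type nitrogen gives a value within the assay's range.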